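The compounds below may be only part of what the source reports. "The series", "measured", "known", "first", "only" and "open" are said of these compounds alone.

Measured so far in a functional assay on CHO cells for agonist activity at Alpha-1D adrenergic receptor (Homo sapiens), read by FLIPR and calcium flux; on this read-out higher numbers stand for an effect only at larger amounts of compound and lower numbers for an effect already at smaller amounts:
compound 1, `COc1c(Cl)ccc2c1CCC2c1ncc[nH]1`, gives > 10000 nM, which is a limit of the assay and not a number.
compound 2, `c1ccc(-c2cccc3c2CCC3c2ncc[nH]2)nc1`, gives > 10000 nM, again a limit of the assay.
compound 3, `c1ccc2c(c1)CCCC2c1ncc[nH]1`, gives 364 nM.

Compound 2 therefore stands at the limit in this assay; only a limit, no number, is known for it, and one further value shown, that of compound 1, is a limit as well. Two of the three values sit at the limit of > 10000 nM in this assay, at which 2 of the 3 values shown sit, so compound 3 alone gives a number, and it carries no group at all on its six-membered aromatic ring of carbon only.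

Compound 4, `c1cc(-c2ncco2)c2c(c1)C(c1ncc[nH]1)CC2`, is the next compound for this assay. It differs from compound 2 in one place: 1,3-oxazol-2-yl in place of pyridin-2-yl on an aromatic carbon. Both compound 2 and compound 4 thus carry an aromatic substituent on the six-membered aromatic ring of carbon only, ortho to a fused ring, where compound 3 has none.

Among the compounds with values here, no measured pair differing in a single place is available, so the size of the change cannot be read from the data. Given that compound 2 gives > 10000 nM, a limit, the step of an at least 1.2-fold lower number from compound 2 to compound 4 (0.09 log units; that floor lies within the scatter) is expected to be none beyond the scatter. Compound 4 is expected at about 8000 nM, between 2000 nM and 30000 nM, with a fair chance of only a limit again.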

Compound 4, half-maximal effective concentration: 1390 nM
Compound 4: middle estimate off by 5.8-fold (0.76 log units), on the high side; measured number below the stated range.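

In this assay, 1,3-oxazol-2-yl in place of pyridin-2-yl on an aromatic carbon, ortho to a fused ring, gives an at least 7.1-fold lower number from compound 2 to compound 4 (0.85 log units; beyond the scatter), so the identity of the aromatic group at this place clearly matters. An aromatic substituent on this carbon does not by itself leave the series at the limit: compound 4 carries one and gives a number, whereas compound 2 does not. The step is only a floor, and its full size cannot be read, as the value of compound 2 is a limit and not a number: the limit of > 10000 nM in this assay, at which 2 of the 4 values shown sit.

The exchange changes several things at once, from a six-membered to a five-membered aromatic ring and from one hetero atom to two, and this single pair cannot separate them, so a close relative such as thiazol-2-yl or pyridin-3-yl on the same carbon would be needed to tell which of these carries the step. As far as these compounds go, it also remains open how a non-aromatic group at this place, such as methyl, morpholine or a primary amine, would read on the core of compound 4.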